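The source may report more compounds than this note shows. Statements on the series, on what has been measured and on what is new or still open speak of the compounds shown alone.

Three compounds have been measured so far:

Compound 1, `Nc1scc(-c2cccc(C(F)(F)F)c2)c1C(=O)c1ccccc1`: 6.37
Compound 2, `Nc1scc(-c2ccccc2F)c1C(=O)c1ccc(Cl)cc1`: 5.1
Compound 3, `Nc1scc(-c2cccc(F)c2)c1C(=O)c1ccc(Cl)cc1`: 5.88

All three were tested in an assay on isolated protein with adenosine receptor A1 (Homo sapiens) as the target, read by ERK phosphorylation; a higher number here means a more potent compound, by a factor of ten per unit of this negative logarithm, a lower number a less potent compound. Among them compound 3, with 5.88, stands second; compound 1 gives 6.37, a higher number, while compound 2 gives 5.1, a lower one, both differences lying beyond the scatter. Within the data shown here, the one single-change step available, a number 0.78 log units higher from compound 2 to compound 3 (beyond the scatter), concerns moving a fluorine around the ring and does not touch the change considered here.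

Compound 4, `Nc1scc(-c2cccc(C(F)(F)F)c2)c1C(=O)c1ccc(Cl)cc1`, differs from compound 3 in one place: trifluoromethyl in place of fluoro on an aromatic carbon. Among the measured compounds shown here, no measured pair isolates this swap. Compound 1 does carry a trifluoromethyl on the same ring, but it also differs from compound 3 in its ketone-bearing ring. The value of compound 1, 6.37, can therefore only be taken as a rough pointer. Compound 4 is therefore expected to land near compound 1, a step of a number 0.32 log units higher from compound 3 to compound 4 (beyond the scatter), with an estimated value of 6.2 in a range from 5.6 to 6.8.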

Compound 4, negative logarithm of the antagonist equilibrium constant: 5.74
Compound 4: middle estimate off by 0.46 log units, on the high side; low and high end bracket the measured number.
By their numbers in this assay, from the lowest: compound 2; then compounds 4 and 3 (each within the scatter of the next); then compound 1.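

Trifluoromethyl in place of fluoro on this aromatic carbon gives a number 0.14 log units lower from compound 3 to compound 4 (within the scatter), so in this assay the two groups cannot be told apart at this position, even though trifluoromethyl has four heavy atoms and fluoro has one. With trifluoromethyl kept in place, chloro in place of hydrogen on an aromatic carbon of the ketone-bearing ring gives a number 0.63 log units lower from compound 1 to compound 4 (beyond the scatter), so the higher number of compound 1 goes with the missing chloro and cannot be credited to trifluoromethyl. No measurement shown here gives a reason for either step.

From the compounds shown here alone, it remains open whether chloro in place of hydrogen has the same effect when fluoro sits on the other ring. Also open, going by these compounds, is how a methoxy group, an amine or a carboxylic acid would fare at this position.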